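Opening a ring on the amine: from compound 1 to compound 3

The compounds below may be only part of what the source reports. "The series", "measured", "known", "first", "only" and "open" are said of these compounds alone.

The account follows two measured compounds and one that is yet to be tested. In a functional assay on CHO cells for activation of 5-hydroxytryptamine receptor 1D (Homo sapiens), read by GTPgammaS binding (a lower number here means a smaller maximal response, a higher number a larger maximal response), compound 1 `O[C@@H]1Cc2ccccc2[C@H]1NC1CCN(CCCc2c[nH]c3ccc(-n4cnnc4)cc23)CC1` gives 75% and stands as the lower of the two numbers in hand. Compound 2 `CC(=O)Nc1ccc([C@H](C)NCC2CCN(CCCc3c[nH]c4ccc(-n5cnnc5)cc34)CC2)cc1` gives 99% in this assay, a result that lies beyond the usual scatter above the number for compound 1. Within the data shown here, no single-point step between these two is drawn, since they differ in more than one place.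

Compound 3 `OCCC(NC1CCN(CCCc2c[nH]c3ccc(-n4cnnc4)cc23)CC1)c1ccccc1` shares the core of compound 1 but carries 3-hydroxy-1-phenylpropyl in place of 2-hydroxy-2,3-dihydro-1H-inden-1-yl on the amine nitrogen (3-hydroxy-1-phenylpropyl in place of 2-hydroxy-2,3-dihydro-1H-inden-1-yl on an amine nitrogen). Among the measured compounds shown here, with no step of this kind measured, the expectation rests on compound 1 alone, and a modest rise in this assay is expected, a number 10 percentage points higher from compound 1 to compound 3 (within the scatter), though one that may fall within the scatter. Compound 3 is therefore estimated to reach 85%, with a range from 65% to 100%.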

Compound 3, largest response reached (reported as efficacy), in percent of the reference or control that the assay uses: 100%
For compound 3 the middle estimate is 15 percentage points below the measured one; the range from low to high includes it.
By their numbers in this assay, from the lowest: compound 1; then compounds 2 and 3 (each within the scatter of the next).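

At the amine nitrogen, 3-hydroxy-1-phenylpropyl in place of 2-hydroxy-2,3-dihydro-1H-inden-1-yl gives a number 25 percentage points higher from compound 1 to compound 3 (beyond the scatter) in this assay, the only one-place step shown at this position. The two groups match in heavy atoms, hydrogen-bond donors and hydrogen-bond acceptors, so this change alters the maximal response without altering those counts; what leaves is the five-membered non-aromatic ring of carbon only and the 2 defined stereocentres. Nothing measured here accounts for the size of this step.

The compounds shown leave open whether the maximal response holds if the hydroxy group of the 3-hydroxy-1-phenylpropyl is replaced by an amine or a carboxylic acid. They also leave open what a longer chain in place of the propyl would do at this amine nitrogen.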